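Piperidine nitrogen substituent on an indanone-bearing series

The compounds below may be only part of what the source reports. "The series", "measured", "known", "first", "only" and "open" are said of these compounds alone.

Measured so far:
compound 1 `CCc1cnc(N2CCC(CCCNc3ccc4c(c3)C(=O)CC4)CC2)nc1`: 51 nM
compound 2 `CC(C)(C)OC(=O)N1CCC(CCCNc2ccc3c(c2)CNC3=O)CC1`: 550 nM

In a functional assay on CHO-K1 cells for agonist activity at Glucose-dependent insulinotropic receptor (Homo sapiens), read by HTRF and cAMP accumulation, with a stated time of 30 min (on this read-out higher numbers stand for an effect only at larger amounts of compound and lower numbers for an effect already at smaller amounts), compound 1 gives the lower of the two measured numbers, 51 nM. Compound 2 gives 550 nM, a gap that lies beyond the usual scatter. Compound 2 differs from compound 1 in two places at once, the substituent on the ring nitrogen and the core, so these two values alone do not separate the two changes.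

Compound 3 `CC(C)(C)OC(=O)N1CCC(CCCNc2ccc3c(c2)C(=O)CC3)CC1` is the untested member. It differs from compound 1 by tert-butoxycarbonyl in place of 5-ethylpyrimidin-2-yl on an amine nitrogen in a ring. Among the compounds with values here, no measured pair isolates this single change. Within the data shown here, the only tert-butoxycarbonyl-bearing compound measured, compound 2, sits at 550 nM, which points toward a weaker compound.

The step from compound 1 to compound 3 in this assay is therefore expected to be a 5.9-fold higher number from compound 1 to compound 3 (0.77 log units; beyond the scatter), toward higher numbers and beyond the scatter. Compound 3 is estimated at 300 nM, with a range from 100 nM to 1500 nM.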

Compound 3, half-maximal effective concentration: 46 nM
Beside the measured number, compound 3's estimate is 6.5-fold (0.81 log units) above it, outside the stated range (below it).
By their numbers in this assay, from the lowest: compounds 3 and 1 (each within the scatter of the next); then compound 2.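

In this assay, within the data shown here, the exchange of 5-ethylpyrimidin-2-yl for tert-butoxycarbonyl on the amine nitrogen in the ring is the first single change read at this position, and the step is a 1.1-fold lower number from compound 1 to compound 3 (0.04 log units; within the scatter). At this position, then, the two groups are not told apart on this read-out, although one brings a six-membered aromatic ring and the other no ring, so the higher number of compound 2 at 550 nM cannot be laid on tert-butoxycarbonyl alone. Nothing at hand explains why the two groups read alike.

Still open, on these data alone, is whether a free ring amine, a small acetyl group or a carboxylic acid at this nitrogen would read the same. Also open, as far as these compounds go, is whether 5-ethylpyrimidin-2-yl and tert-butoxycarbonyl read alike on the core of compound 2.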